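The source may hold more compounds than are shown below. What is called first, only, known or untested is meant among the compounds shown, and "the series" means these compounds.

Compound 1 `Cc1ccc(C)c(NC(=O)CSc2nnc(-c3ccoc3C)n2Cc2ccco2)c1` is an amide built on the shared core. In a functional assay on CHO cells for antagonist activity at Orexin receptor type 2 (Homo sapiens), read by FLIPR and calcium flux (on this read-out lower numbers stand for stronger inhibition and higher numbers for weaker inhibition), compound 1 gives 398 nM, the higher of the two numbers measured here, though compound 3 `CC(=O)c1cccc(NC(=O)CSc2nnc(-c3ccoc3C)n2Cc2ccco2)c1`, which gives 316 nM in this assay, lies within the scatter of it. Compound 2 `Cc1cccc(NC(=O)CSc2nnc(-c3ccoc3C)n2Cc2ccco2)c1C` gives only a limit of this assay, > 15800 nM, and no number. Compound 4 `Cc1occc1-c1nnc(SCC(=O)Nc2ccc(N(C)C)cc2)n1Cc1ccco1` has not yet been measured; it differs from compound 1 in one place: 4-(dimethylamino)phenyl in place of 2,5-dimethylphenyl on an amide-type nitrogen. Within the data shown here, no measured step touches this exact pattern of substitution, so the guidance is indirect. The step of an at least 39-fold higher number from compound 1 to compound 2 (1.59 log units; beyond the scatter) shows how severe a change within this group can be, and an at least 50-fold lower number from compound 2 to compound 3 (1.69 log units; beyond the scatter) shows the same gap in reverse, while a 1.3-fold lower number from compound 1 to compound 3 (0.10 log units; within the scatter) shows that another replacement of the whole group costs nothing beyond the scatter. A 4-(dimethylamino)phenyl is a third pattern, untested here, so a weakening of modest size is expected, with wide uncertainty in both directions. For compound 4 in this assay the expected step is a 2.3-fold higher number from compound 1 to compound 4 (0.35 log units; beyond the scatter). Compound 4 is therefore estimated at 900 nM, within a range from 200 nM to 6000 nM.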

Compound 4, inhibition constant: 158 nM
Compound 4: middle estimate off by 5.7-fold (0.76 log units), on the high side; measured number outside the range, below it.
By their numbers in this assay, from the lowest: compounds 4, 3 and 1 (each within the scatter of the next, the first and the last beyond it). At a limit, above all of these: compound 2.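

Among these compounds, compound 4 is the first compound here to move beyond the scatter in the stronger direction from compound 1, showing that the group on the amide-type nitrogen can bring a gain as well as a loss in this assay: a 2.5-fold lower number from compound 1 to compound 4 (0.40 log units; beyond the scatter), whereas a 2.0-fold lower number from compound 3 to compound 4 (0.30 log units; within the scatter) leaves compound 4 and compound 3 level. The new group, 4-(dimethylamino)phenyl, brings a nitrogen and a hydrogen-bond acceptor that 2,5-dimethylphenyl lacks, and an at least 100-fold lower number from compound 2 to compound 4 (2.00 log units; beyond the scatter) widens the span of outcomes seen at this one place. Compound 2 still gives a limit of the assay and not a number: the limit of > 15800 nM in this assay, at which 1 of the 4 values shown sits.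

The compounds shown cannot separate what the dimethylamino group contributes from what is lost with the methyl groups of 2,5-dimethylphenyl, since both change in the same step. On these data alone, it also remains open how a simple 4-aminophenyl, a 4-methoxyphenyl or a morpholine ring in place of the dimethylamino group would behave at this place, and so whether the nitrogen itself matters.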